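The compounds below may be only part of what the source reports. "The series", "measured", "known", "first", "only" and "open" are said of these compounds alone.

Measured compounds in a functional assay on A549 cells (Homo sapiens) for antiproliferative activity, read by MTT assay, with a stated time of 72 h; a higher number here means a weaker inhibitor, a lower number a stronger inhibitor:
compound 1 `COc1cc2ncnc(Nc3ccc(F)c(Cl)c3)c2cc1OCCCCC(=O)Nc1ccc(S(N)(=O)=O)cc1`, 15500 nM
compound 2 `COc1cc2ncnc(Nc3ccc(Cl)c(C(F)(F)F)c3)c2cc1OCCCCC(=O)Nc1ccc(S(N)(=O)=O)cc1`, 9270 nM
compound 3 `COc1cc2ncnc(Nc3cccc(F)c3)c2cc1OCCCCC(=O)Nc1ccc(S(N)(=O)=O)cc1`, limit only

Compound 3 stands at the weak end of the set. In this assay compound 3 gives > 40000 nM, which is a limit of the assay rather than a number. The steps of an at least 2.5-fold higher number from compound 1 to compound 3 (0.41 log units; beyond the scatter) and an at least 4.3-fold higher number from compound 2 to compound 3 (0.63 log units; beyond the scatter) are therefore only lower bounds on the loss, while the step of a 1.7-fold lower number from compound 1 to compound 2 (0.22 log units; within the scatter) is within the scatter.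

Compound 4 `COc1cc2ncnc(Nc3ccc(F)cc3)c2cc1OCCCCC(=O)Nc1ccc(S(N)(=O)=O)cc1` differs from compound 3 by 4-fluorophenyl in place of 3-fluorophenyl on a nitrogen on an aromatic ring. Within the data shown here, none of the measured steps moves the fluorine to another position on that ring; the two informative steps both replace a disubstituted phenyl by 3-fluorophenyl and both end at the limit. Among the measured compounds shown here, no measured step bears directly on this change, so no step beyond the scatter is expected in this assay in either direction.

Compound 4 is expected to give 45000 nM (range 20000 nM to 100000 nM), a step that the limit leaves unreadable from compound 3 to compound 4, with a real chance that only the limit is reported again.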

Compound 4, half-maximal inhibitory concentration: > 40000 nM
Compound 4 ended at the assay's limit; the forecaster's own chance of this, stated with the estimate: 65%; the middle value lies beyond the limit too.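

In this assay compound 4 gives > 40000 nM, which is a limit of the assay and not a number. The steps of an at least 4.3-fold higher number from compound 2 to compound 4 (0.63 log units; beyond the scatter) and an at least 2.5-fold higher number from compound 1 to compound 4 (0.41 log units; beyond the scatter) are lower bounds only, and they show that 4-fluorophenyl, like 3-fluorophenyl in compound 3, falls short of both disubstituted phenyl groups in compound 1 and compound 2. The step between compound 3 and compound 4 cannot be read, with both compounds sitting at the same limit: the limit of > 40000 nM in this assay, at which 2 of the 4 values shown sit.

Going by these compounds, how far compound 3 and compound 4 lie past the limit, and so whether the place of the fluorine matters at all, remains open. Also open, on these data alone, is whether a single bromo or methoxy group on that phenyl ring would restore a measurable value in this assay, or whether two substituents are needed.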